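Furan-2-yl in place of phenyl, chloro compounds

The source may report more compounds than this note shows. Statements on the series, on what has been measured and on what is new or still open speak of the compounds shown alone.

Among the compounds with values here, in a functional assay on A549 cells (Homo sapiens), read by sulforhodamine B assay, with a stated time of 5 days (a higher number here means a weaker inhibitor of growth, a lower number a stronger inhibitor of growth), compound 3 (`OC[C@H]1O[C@@H](n2cc(Cl)c3c(-c4ccccc4)ncnc32)[C@H](O)[C@@H]1O`) gives 2500 nM, the higher of the two numeric values so far, and compound 2 (`OC[C@H]1O[C@@H](n2cc(F)c3c(-c4ccco4)ncnc32)[C@H](O)[C@@H]1O`) gives 110 nM. Compound 1 (`OC[C@H]1O[C@@H](n2cc(F)c3c(-c4ccccc4)ncnc32)[C@H](O)[C@@H]1O`) gives > 10000 nM, which is a limit of the assay and not a number. Compound 4 (`OC[C@H]1O[C@@H](n2cc(Cl)c3c(-c4ccco4)ncnc32)[C@H](O)[C@@H]1O`) carries furan-2-yl in place of phenyl on an aromatic carbon. Within the data shown here, the same exchange gave an at least 90-fold lower number from compound 1 to compound 2 (1.95 log units; beyond the scatter), the closest precedent, while chloro in place of fluoro gave an at least 4.0-fold lower number from compound 1 to compound 3 (0.60 log units; beyond the scatter). Both steps start from the limit (the limit of > 10000 nM in this assay, at which 1 of the 3 values shown sits), so their true sizes are open. A large step to a lower number is therefore expected. Compound 4 is estimated at 30 nM, within 8 nM to 120 nM. The expected change is an 83-fold lower number from compound 3 to compound 4 (1.92 log units; beyond the scatter).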

Compound 4, concentration for 50% growth inhibition: > 10000 nM
Compound 4 ended at the assay's limit; the forecaster's own chance of this, stated with the estimate: 3%; middle value at least 330-fold (2.52 log units) away from the limit.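

In this assay, furan-2-yl in place of phenyl does not carry over from the fluoro compounds to the chloro compounds, giving an at least 4.0-fold higher number from compound 3 to compound 4 (0.60 log units; beyond the scatter) here, so its outcome at this position depends on the halogen: the same change on two cores in this assay, an at least 90-fold lower number (1.95 log units; beyond the scatter) from compound 1 to compound 2 and an at least 4.0-fold higher number (0.60 log units; beyond the scatter) from compound 3 to compound 4, at least 360-fold (2.56 log units) apart, beyond the scatter of two such steps. Chloro in place of fluoro likewise depends on the group on the aromatic carbon, giving an at least 90-fold higher number from compound 2 to compound 4 (1.95 log units; beyond the scatter) with furan-2-yl present: the same change on two cores in this assay, an at least 4.0-fold lower number (0.60 log units; beyond the scatter) from compound 1 to compound 3 and an at least 90-fold higher number (1.95 log units; beyond the scatter) from compound 2 to compound 4, at least 360-fold (2.56 log units) apart, beyond the scatter of two such steps. Going by these compounds, compound 4 gives > 10000 nM, which is a limit of the assay, so the true size of both new steps stays open: the limit of > 10000 nM in this assay, at which 2 of the 4 values shown sit.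

On these data alone, the four compounds form a single set of pairs, so it remains open whether bromo in place of chloro would keep or lose the low number seen with furan-2-yl and fluoro. As far as these compounds go, how an amine on that aromatic carbon would behave also remains open.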